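Methoxy for Methylsulfanyl in a Weakly Active Nucleoside Set

The source may hold more compounds than are shown below. What is called first, only, known or untested is meant among the compounds shown, and "the series" means these compounds.

Of the compounds shown here, three have been measured in a functional assay on HCT-116 cells (Homo sapiens), read by MTT assay, with a stated time of 72 h; a lower number here means a stronger inhibitor, a higher number a weaker inhibitor. Compound 1 `CSc1ncnc2c1c(-c1ccccc1)cn2[C@@H]1O[C@H](CO)[C@@H](O)[C@H]1O` gives only a limit there, > 20000 nM, so no number is known for it (the limit of > 20000 nM in this assay, at which 2 of the 3 values shown sit). Compound 2 `Nc1nc2c(c(-c3ccco3)cn2[C@@H]2O[C@H](CO)[C@@H](O)[C@H]2O)c(=O)[nH]1` likewise reaches only a limit, > 20000 nM. Compound 3 `Nc1nc2c(c(-c3cccs3)cn2[C@@H]2O[C@H](CO)[C@@H](O)[C@H]2O)c(=O)[nH]1` gives 19800 nM. Among the compounds with values here, the single measured step, a number no higher from compound 2 to compound 3 (the limit leaves the size open), concerns a different change and does not bear on the one considered here. Compound 4 `COc1ncnc2c1c(-c1ccccc1)cn2[C@@H]1O[C@H](CO)[C@@H](O)[C@H]1O` differs from compound 1 by methoxy in place of methylsulfanyl on an aromatic carbon. Within the data shown here, no measured step covers this exchange, so the expectation rests on compound 1 alone, whose limit is > 20000 nM. Compound 4 is therefore expected to remain weak, most likely again as a limit, with an estimate of 30000 nM in a range of 8000 nM to 100000 nM. The expected step is a step that the limit leaves unreadable from compound 1 to compound 4, nothing beyond the scatter.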

Compound 4, half-maximal inhibitory concentration: > 20000 nM
Compound 4 ended at the assay's limit; the forecaster's own chance of this, stated with the estimate: 75%; the middle value does not contradict the limit.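

In this assay compound 1 and compound 4 both end at a limit, so no step between them can be read: the limit of > 20000 nM in this assay, at which 3 of the 4 values shown sit.

On these data alone, how methoxy and methylsulfanyl compare in strength on the shared core of compound 1 and compound 4 stays open.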